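A Bromo-Hydroxyphenyl Imine Tested Against Monoamine Oxidase B

A few compounds are considered here, and "the series" means these few. Any claim that something is new, unique, unknown or untested is made for them only; others in the source may bear on it.

Measured compounds:
compound 1 `Oc1ccc(/C=N/c2ccc(OCc3ccccc3)cc2)c(O)c1`: 6780 nM
compound 2 `Cc1ccc(/C=N/c2ccc(OCc3ccccc3)cc2)c(O)c1`: 24400 nM

Among the measured compounds shown here, in an assay on isolated protein for inhibition of Amine oxidase [flavin-containing] B (Homo sapiens), read by fluorescence and Amplex Red, with stated times of 15 min and 20 min (on this read-out lower numbers stand for stronger inhibition and higher numbers for weaker inhibition), compound 1 gives 6780 nM, the lowest of the two numbers measured so far. For the measured compounds named here, compound 2 gives 24400 nM, and the single step between them, a 3.6-fold higher number from compound 1 to compound 2 (0.56 log units; beyond the scatter), comes with methyl in place of hydroxy on an aromatic carbon.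

Compound 3 `Oc1ccc(Br)cc1/C=N/c1ccc(OCc2ccccc2)cc1` has not yet been measured. It differs from compound 1 by 5-bromo-2-hydroxyphenyl in place of 2,4-dihydroxyphenyl on a carbon with a double bond to nitrogen. Going by the values given here, only one measured step bears on this change, and it shows that losing the second hydroxy group cost a modest amount. Among the compounds with values here, compound 3 also loses that hydroxy, while a bromine enters elsewhere on the same ring, something no measured pair informs. A modestly higher number is therefore expected for compound 3, roughly a 1.8-fold higher number from compound 1 to compound 3 (0.25 log units; within the scatter), though a value close to compound 1 cannot be ruled out. The estimate for compound 3 is 12000 nM, with a range from 3500 nM to 40000 nM.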

Compound 3, half-maximal inhibitory concentration: 31700 nM
Compound 3: the middle estimate sits 2.6-fold (0.42 log units) below what was measured; the measured number falls inside the stated range.
By their numbers in this assay, from the lowest: compound 1; then compounds 2 and 3 (each within the scatter of the next).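

Swapping 2,4-dihydroxyphenyl for 5-bromo-2-hydroxyphenyl gives a clear loss (a 4.7-fold higher number from compound 1 to compound 3 (0.67 log units; beyond the scatter)), so a bromine on this ring does not restore the lower number of compound 1. Two quite different replacements now end up in the same place: the step between them (a 1.3-fold higher number from compound 2 to compound 3 (0.11 log units; within the scatter)) is no larger than repeat measurements would give, and across these three compounds, only the 2,4-dihydroxyphenyl group gives the lowest number. No measurement here explains why this group stands apart.

From the compounds shown here alone, compound 3 changes two things at once, so the separate contribution of the bromine stays unknown. Going by these compounds, it also remains open whether a methoxy group or an amine could stand in for the lost hydroxy and keep the number of compound 1.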